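The source may hold more compounds than are shown below. What is called first, only, known or untested is meant among the compounds shown, and "the series" means these compounds.

Compound 1 `CCOC(=O)c1noc2c1CN(C(=O)c1cc(C(C)C)c(O)cc1O)CC2`: 563 nM
Compound 2 `CCNC(=O)c1noc(-c2cc(C(C)C)c(O)cc2O)c1NC(=O)C1CCC(OC)CC1`: 15 nM

In an ADME assay on L6 cells (Rattus norvegicus) for cytotoxicity (a lower number here means a stronger inhibitor, a higher number a weaker inhibitor), compound 1 stands at 563 nM and compound 2 at 15 nM, so compound 2 has the lower of the two numbers. The gap between the two lies well beyond the scatter. Compound 3 `CCNC(=O)c1noc(-c2cc(C(C)C)c(O)cc2O)c1NC(=O)[C@@H]1CC[C@H](C(=O)OC)C1` keeps the rest of compound 2 but carries 3-(methoxycarbonyl)cyclopentyl in place of 4-methoxycyclohexyl on a carbonyl carbon. Among the compounds with values here, no measured pair shows what this swap does, so only a modest rise in the number is expected in this assay, meaning a somewhat weaker inhibitor: the expected step is a 2.3-fold higher number from compound 2 to compound 3 (0.37 log units; beyond the scatter). For compound 3 the estimated value is 35 nM, with an expected range of 9 nM to 140 nM.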

Compound 3, half-maximal inhibitory concentration: 40 nM
The estimate for compound 3 lay 1.1-fold (0.06 log units) below the measured number, and the stated range covers the measured number.
By their numbers in this assay, from the lowest: compound 2; then compound 3; then compound 1.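

In this assay the position on the carbonyl carbon now has its first one-place comparison: 3-(methoxycarbonyl)cyclopentyl in place of 4-methoxycyclohexyl gives a 2.7-fold higher number from compound 2 to compound 3 (0.43 log units; beyond the scatter) and so a modestly weaker inhibitor. The ring size and the group on the ring change together in this single step, so their separate contributions cannot be read. No supporting measurement explains the shift.

Which of the two changes matters remains open. A plain cyclopentyl group, or a carboxylic acid in place of the methyl ester, would help separate them.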